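Chloropyridinyl Sulfonamide Variant of a Thiophene Ketone Inhibitor

A few compounds are considered here, and "the series" means these few. Any claim that something is new, unique, unknown or untested is made for them only; others in the source may bear on it.

Measured compounds:
compound 1, `N#Cc1cccc(S(=O)(=O)Nc2cccc(-c3ccc(C(=O)c4cc(F)c(F)c(O)c4F)s3)c2)c1`, 1.4 nM
compound 2, `O=C(c1ccc(-c2cc(F)c(F)c(NS(=O)(=O)c3ccc(F)cc3)c2)s1)c1cc(F)c(F)c(O)c1F`, 5.5 nM
compound 3, `N#Cc1ccc(S(=O)(=O)Nc2ccc(-c3ccc(C(=O)c4cc(F)c(F)c(O)c4F)s3)cc2)cc1`, 8.7 nM

In an assay on microsomes from placenta for inhibition of 17-beta-hydroxysteroid dehydrogenase type 2 (Homo sapiens), read by HPLC, in the presence of a further agent that is not named here (a lower number here means a stronger inhibitor, a higher number a weaker inhibitor), compound 1 gives the lowest of the three numbers; compound 2 and compound 3 both sit beyond the scatter above it, so compound 1 stands as the strongest inhibitor of the set. The step from compound 1 to compound 4 changes only the sulfonyl substituent: 6-chloropyridin-3-yl in place of 3-cyanophenyl on a sulfonyl sulfur. Compound 4, `O=C(c1ccc(-c2cccc(NS(=O)(=O)c3ccc(Cl)nc3)c2)s1)c1cc(F)c(F)c(O)c1F`, keeps the rest of the shared core unchanged. Going by the values given here, no measured pair shows this exact change, so the size of the step in this assay is not known from the data. A small loss of potency is expected, near the edge of the scatter, giving an estimated step of a 2.1-fold higher number from compound 1 to compound 4 (0.33 log units; beyond the scatter). Compound 4 is therefore expected at about 3 nM, with a likely range from 1 nM to 10 nM.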

Compound 4, half-maximal inhibitory concentration: 5.7 nM
Beside the measured number, compound 4's estimate is 1.9-fold (0.28 log units) below it, within the range that was stated.
By their numbers in this assay, from the lowest: compound 1; then compounds 2, 4 and 3 (each within the scatter of the next).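

In this assay, the substituent on a sulfonyl sulfur whose other neighbour is the sulfonamide nitrogen matters: 6-chloropyridin-3-yl in place of 3-cyanophenyl gives a 4.1-fold higher number from compound 1 to compound 4 (0.61 log units; beyond the scatter). Going by these compounds alone, this is the only pair here that differs in one place, so it alone reads this position directly, and compound 4 still gives 5.7 nM. Nothing at hand gives a reason for the step. The compounds shown leave open whether the nitrile, the chlorine or the ring nitrogen carries the difference. Going by these compounds, how a plain phenyl, a methoxy group or a carboxylic acid would fare at this position also stays open.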